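Cyclopentyl amine in place of the branched amine carbon

The source may report more compounds than this note shows. Statements on the series, on what has been measured and on what is new or still open speak of the compounds shown alone.

Three measured compounds share one core and differ only in the group carried on a saturated chain carbon bound to an amine nitrogen and a saturated chain carbon. Compound 1 `N[C@@H](CC1CCCCC1)CN(C(=O)[C@@H]1C[C@H]1c1ccccc1)c1ccc(-c2ccccc2)cc1` gives 1.7 nM in a functional assay for agonist activity at G protein-coupled receptor 88 (Homo sapiens), read by HTRF and cAMP accumulation; a lower number here means that less compound is needed, a higher number that more compound is needed for the effect. Compound 2 `N[C@H](CN(C(=O)[C@@H]1C[C@H]1c1ccccc1)c1ccc(-c2ccccc2)cc1)C1CCCCC1` gives 0.66 nM. Compound 3 `CC(C)[C@H](N)CN(C(=O)[C@@H]1C[C@H]1c1ccccc1)c1ccc(-c2ccccc2)cc1` gives 1.1 nM, second highest of the three numbers, with both neighbours within the scatter: a 1.5-fold lower number from compound 1 to compound 3 (0.19 log units; within the scatter) and a 1.7-fold higher number from compound 2 to compound 3 (0.22 log units; within the scatter). Only a 2.6-fold lower number from compound 1 to compound 2 (0.41 log units; beyond the scatter) exceeds the scatter. Compound 4 `NC1(CN(C(=O)[C@@H]2C[C@H]2c2ccccc2)c2ccc(-c3ccccc3)cc2)CCCC1` carries 1-aminocyclopentyl in place of 1-amino-2-methylpropyl on a saturated chain carbon bound to an amide-type nitrogen. Within the data shown here, no measured step closes a ring on the amine-bearing carbon, so the bearing of the three steps is indirect; they show that changes at this carbon stay small. Compound 4 is therefore expected near compound 3, with a 1.5-fold higher number from compound 3 to compound 4 (0.16 log units; within the scatter), estimated at 1.6 nM (range 0.5 nM to 6 nM).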

Compound 4, half-maximal effective concentration: 0.57 nM
Compound 4: middle estimate off by 2.8-fold (0.45 log units), on the high side, within the range that was stated.
By their numbers in this assay, from the lowest: compounds 4, 2, 3 and 1 (each within the scatter of the next, the first and the last beyond it).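

The 1-aminocyclopentyl group, which has a ring and no defined stereocentre, is accommodated on a saturated chain carbon bound to an amide-type nitrogen: a 1.9-fold lower number from compound 3 to compound 4 (0.29 log units; within the scatter), and a 1.2-fold lower number from compound 2 to compound 4 (0.06 log units; within the scatter). Only a 3.0-fold lower number from compound 1 to compound 4 (0.47 log units; beyond the scatter) lies beyond the scatter, so a stereocentre at this carbon is not needed for a low number in this assay. Nothing measured here accounts for the result. Open, from the compounds shown here alone, are the ring size, as with 1-aminocyclobutyl or 1-aminocyclohexyl, and the effect of a methylamine in place of the primary amine.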